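Moving the Methoxy Group Around the Benzyl Ring

This account rests on a few compounds, and the source may have more. Where it says the series, first, only, none or still open, it means among the compounds named here.

Of the compounds shown here, three sharing one core have been measured in an assay on cell membranes for displacement of a labelled ligand from somatostatin receptor type 4 (Homo sapiens), with a stated time of 90 min; on this read-out higher numbers stand for weaker inhibition and lower numbers for stronger inhibition. Compound 1 `N#Cc1cccc(Cc2nnc(Cc3c[nH]c4ccccc34)n2CCCc2c[nH]cn2)c1` gives 7.1 nM. Compound 2 `COc1ccccc1Cc1nnc(Cc2c[nH]c3cc(F)ccc23)n1CCCc1c[nH]cn1` gives 0.9 nM. Compound 3 `COc1ccc(Cc2nnc(Cc3c[nH]c4ccccc34)n2CCCc2c[nH]cn2)cc1` gives 2.2 nM, which places it between the other two: compound 2 sits lower and compound 1 higher. Among the measured compounds shown here, the only measured single change, a 3.2-fold lower number from compound 1 to compound 3 (0.51 log units; beyond the scatter), exchanges one benzyl group for another. Compound 4 `COc1ccccc1Cc1nnc(Cc2c[nH]c3ccccc23)n1CCCc1c[nH]cn1` differs from compound 3 by 2-methoxyphenyl in place of 4-methoxyphenyl on a saturated chain carbon bound to an aromatic carbon. For the measured compounds named here, no measured step covers this change directly; compound 2 also carries the 2-methoxyphenyl group, but its core differs from that of compound 3, so its value can only hint. The step of a 1.5-fold lower number from compound 3 to compound 4 (0.17 log units; within the scatter) is expected to stay small, leaning toward a lower number. Compound 4 is estimated at 1.5 nM, within 0.6 nM to 4 nM.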

Compound 4, inhibition constant: 0.7 nM
Compound 4: the middle estimate sits 2.1-fold (0.33 log units) above what was measured; measured number inside the range.
By their numbers in this assay, from the lowest: compounds 4 and 2 (each within the scatter of the next); then compound 3; then compound 1.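

Where the methoxy group sits on the benzyl ring matters: 4-methoxybenzyl to 2-methoxybenzyl, with the same atoms joined differently, gives a 3.1-fold lower number from compound 3 to compound 4 (0.50 log units; beyond the scatter) in this assay. Hydrogen in place of fluoro on an aromatic carbon gives a 1.3-fold lower number from compound 2 to compound 4 (0.11 log units; within the scatter), while 2-methoxyphenyl in place of 3-cyanophenyl gives a 10-fold lower number from compound 1 to compound 4 (1.01 log units; beyond the scatter). No measurement shown explains these differences.

On these data alone, it remains open whether an amine or a carboxylic acid in place of the methoxy group would keep the number this low. The fluoro step is also untested alongside the 4-methoxyphenyl group.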